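The source may report more compounds than this note shows. Statements on the series, on what has been measured and on what is new or still open speak of the compounds shown alone.

In a functional assay on M21 cells (Homo sapiens) for inhibition, read by sulforhodamine B assay, with a stated time of 48 h (a lower number here means a stronger inhibitor of growth, a higher number a weaker inhibitor of growth), compound 1 (`O=C(CCl)NC(=O)Nc1ccc(-c2ccccc2)cc1`) gives 1400 nM, compound 2 (`O=C(CCl)NC(=O)Nc1ccc(OC2CCCCC2)cc1`) gives 5000 nM and compound 3 (`O=C(CCl)NC(=O)Nc1ccc(I)cc1`) gives 4200 nM. Compound 3 thus stands second highest by rank, but it cannot be separated from compound 2: a 1.2-fold lower number from compound 2 to compound 3 (0.08 log units; within the scatter). Compound 4 (`Cc1ccc(NC(=O)NC(=O)CCl)cc1`) has methyl in place of iodo on an aromatic carbon, (methyl in place of iodo on an aromatic carbon). Going by the values given here, no measured compound carries methyl, so only the sizes of the steps at this carbon bear on the change. Both are modest: a 3.0-fold higher number from compound 1 to compound 3 (0.48 log units; beyond the scatter) and a 3.6-fold higher number from compound 1 to compound 2 (0.55 log units; beyond the scatter). A modest move to a higher number is therefore expected, as a 1.5-fold higher number from compound 3 to compound 4 (0.19 log units; within the scatter). For compound 4 the estimated value is 6500 nM, with an expected range of 2800 nM to 15000 nM.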

Compound 4, concentration for 50% growth inhibition: 4900 nM
Beside the measured number, compound 4's estimate is 1.3-fold (0.12 log units) above it, within the range that was stated.
By their numbers in this assay, from the lowest: compound 1; then compounds 3, 4 and 2 (each within the scatter of the next).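

In this assay, methyl at this aromatic carbon cannot be told apart from iodo (a 1.2-fold higher number from compound 3 to compound 4 (0.07 log units; within the scatter)) or from cyclohexyloxy (a 1.0-fold lower number from compound 2 to compound 4 (0.01 log units; within the scatter)), so these three groups now form one level within the scatter. Phenyl alone stands apart from that level, and methyl confirms it (a 3.5-fold higher number from compound 1 to compound 4 (0.54 log units; beyond the scatter)), a step beyond the scatter and of the same modest size as those from phenyl to the other two groups. Nothing measured here accounts for phenyl standing apart. The compounds shown leave open how an amine or a carboxylic acid at this carbon would compare. They also leave open whether a longer chain or a pyridine ring would reach the number of compound 1.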